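Sulfonamide chain variation on the shared core

A few compounds are considered here, and "the series" means these few. Any claim that something is new, unique, unknown or untested is made for them only; others in the source may bear on it.

Within the data shown here, compound 3 `CCC1C(=O)N(C)c2cnc(Nc3ccc(S(=O)(=O)NCC(C)C)cc3)nc2N1c1ccn(C)n1` gives 5310 nM in a functional assay on HeLa cells (Homo sapiens) for antiproliferative activity, read by CCK-8 assay, with a stated time of 72 h (on this read-out lower numbers stand for stronger inhibition of growth and higher numbers for weaker inhibition of growth), the second highest of the three numbers known. Compound 2 `CCC1C(=O)N(C)c2cnc(Nc3ccc(S(=O)(=O)NCCCO)cc3)nc2N1c1ccn(C)n1` gives 23700 nM, and compound 1 `CC[C@@H]1C(=O)N(C)c2cnc(Nc3ccc(S(N)(=O)=O)cc3)nc2N1C1CCCC1` gives 317 nM; compound 1 differs from both of the others in several places. Among the measured compounds shown here, the one single-point step known, a 4.5-fold lower number from compound 2 to compound 3 (0.65 log units; beyond the scatter), replaced 2-hydroxyethyl with isopropyl. Compound 4 `CCCCNS(=O)(=O)c1ccc(Nc2ncc3c(n2)N(c2ccn(C)n2)C(CC)C(=O)N3C)cc1` differs from compound 3 by propyl in place of isopropyl on a saturated chain carbon bound to a sulfonamide nitrogen. For the measured compounds named here, no measured step shows a branched-to-straight swap of this kind, and the hydroxyl removal of the step to compound 3 bears on it only loosely; a step within the scatter is expected, so compound 4 is estimated at 5000 nM (2000 nM to 13000 nM), meaning a 1.1-fold lower number from compound 3 to compound 4 (0.03 log units; within the scatter).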

Compound 4, concentration for 50% growth inhibition: 4320 nM
The estimate for compound 4 lay 1.2-fold (0.06 log units) above the measured number; low and high end bracket the measured number.
By their numbers in this assay, from the lowest: compound 1; then compounds 4 and 3 (each within the scatter of the next); then compound 2.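

In this assay, propyl in place of isopropyl on a saturated chain carbon bound to a sulfonamide nitrogen gives a 1.2-fold lower number from compound 3 to compound 4 (0.09 log units; within the scatter), so this change of chain shape does not separate the two compounds. Methyl in place of hydroxy, three bonds along the chain from the sulfonamide nitrogen, gives a 5.5-fold lower number from compound 2 to compound 4 (0.74 log units; beyond the scatter), a second step beyond the scatter away from the hydroxylated chain of compound 2.

Still open, from the compounds shown here alone, is how a longer chain, or an amine or carboxylic acid on the butyl chain, would read. No supporting data explain either step.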